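The source may report more compounds than this note shows. Statements on the series, on what has been measured and on what is new or still open speak of the compounds shown alone.

Of the compounds shown here, three have so far been measured in a functional assay on NCI-H460 cells (Homo sapiens) for inhibition, read by MTT assay, with a stated time of 48 h; on this read-out higher numbers stand for weaker inhibition of growth and lower numbers for stronger inhibition of growth. Compound 1 `COc1ccc(-c2cc(-c3ccc([N+](=O)[O-])cc3)[nH]n2)cc1` gives 18300 nM in this assay, and compound 2 `COc1ccc(-c2cc(-c3ccc(Br)cc3)n[nH]2)cc1` gives 27100 nM in this assay. Compound 3 `COc1ccccc1-c1cc(-c2ccccc2-c2ccccc2)n[nH]1` gives 9100 nM in this assay, the lowest of the three numbers; its gap to compound 1 lies within the scatter, and only its gap to compound 2 lies beyond it. Compound 4 `Oc1ccccc1-c1cc(-c2ccccc2-c2ccccc2)n[nH]1` has not yet been measured. It differs from compound 3 by hydrogen in place of methyl on an oxygen on an aromatic ring. No step of this kind has been measured among these compounds, so no size can be read from them; a shift no larger than the scatter is expected, in either direction. That step is estimated as a 1.0-fold lower number from compound 3 to compound 4 (0.00 log units; within the scatter) in this assay. For compound 4 a value of 9000 nM is expected, with a range from 3000 nM to 27000 nM.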

Compound 4, concentration for 50% growth inhibition: 4600 nM
Beside the measured number, compound 4's estimate is 2.0-fold (0.29 log units) above it, and the stated range covers the measured number.
By their numbers in this assay, from the lowest: compounds 4, 3, 1 and 2 (each within the scatter of the next, the first and the last beyond it).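

In this assay, within the data shown here, the swap of 2-methoxyphenyl for 2-hydroxyphenyl gives a 2.0-fold lower number from compound 3 to compound 4 (0.30 log units; within the scatter) as the only step on hand at this oxygen on an aromatic ring. The methyl on this oxygen can therefore give way to hydrogen with no shift beyond the scatter. No measurement on hand bears on this step. The compounds shown leave open whether an ethyl or a longer chain on this oxygen, or an amine in place of the hydroxy, would stay within the scatter of compound 3. They also leave open whether the same step holds on the core of compound 1.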